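A Pyridone Gives Way to a Fluoromethoxyphenyl Ring

A few compounds are considered here, and "the series" means these few. Any claim that something is new, unique, unknown or untested is made for them only; others in the source may bear on it.

Compound 1, `CC(C)n1nc(-c2ccnc3[nH]c(C4CCN(CC(=O)N(C)C)CC4)cc23)ccc1=O`: 2
Compound 2, `CN(C)C(=O)CN1CCC(c2cc3c(-c4ccc(=O)n(C)c4)ccnc3[nH]2)CC1`: 1.1
Compound 3, `CC(C)Cn1cc(-c2ccnc3[nH]c(C4CCN(CC(=O)N(C)C)CC4)cc23)ccc1=O`: 2

In a physicochemical assay for lipophilicity, using the shake flask method, measured as octanol-water partition, at pH 7.4 (a lower number here means a more polar compound, a higher number a more lipophilic compound), compound 2 stands lowest of the three. Both neighbours lie beyond the scatter above it: the step of a number 0.90 log units lower from compound 1 to compound 2 (beyond the scatter) and the step of a number 0.90 log units higher from compound 2 to compound 3 (beyond the scatter) are each modest and of the same size.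

Compound 4, `COc1cc(F)ccc1-c1ccnc2[nH]c(C3CCN(CC(=O)N(C)C)CC3)cc12`, differs from compound 2 by a group of 9 heavy atoms (7 carbon, 1 oxygen, 1 fluorine; one six-membered aromatic ring of carbon only) in place of a group of 8 heavy atoms (6 carbon, 1 nitrogen, 1 oxygen; one six-membered aromatic ring with 1 hetero atom), on an aromatic carbon. Neither measured step swaps the whole ring for one of carbon only, so both bear on this change only loosely; they show that alterations at this position have shifted the number modestly. For compound 4 the number is expected to move upward by a number 1.50 log units higher from compound 2 to compound 4 (beyond the scatter), a larger step than either measured one. Compound 4 is therefore estimated at 2.6, within 2 to 3.2.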

Compound 4, distribution coefficient: 2.9
Estimate against measurement, compound 4: 0.30 log units below, within the range that was stated.
By their numbers in this assay, from the lowest: compound 2; then compounds 1 and 3 (each within the scatter of the next); then compound 4.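

Placing 4-fluoro-2-methoxyphenyl on this aromatic carbon gives a number 1.80 log units higher from compound 2 to compound 4 (beyond the scatter) and a number 0.90 log units higher from compound 1 to compound 4 (beyond the scatter) in this assay at this position. The first of these is the largest step seen here so far, and in both pairs the ring of carbon only gives the higher number. No measurement shown gives a reason for these steps. As far as these compounds go, the methoxy group and the fluorine enter together, so their separate shares remain unknown. Where a plain phenyl ring, or a phenyl ring carrying an amine or a carboxylic acid, would fall also remains open.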